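Adding an isopropyl to the most active compound

A few compounds are considered here, and "the series" means these few. Any claim that something is new, unique, unknown or untested is made for them only; others in the source may bear on it.

Measured in a functional assay on A549 cells (Homo sapiens) for antiproliferative activity, read by MTT assay, with a stated time of 72 h; on this read-out higher numbers stand for weaker inhibition and lower numbers for stronger inhibition:
Compound 1 `COc1cccc(Nc2nc3c(c(Oc4cccc(NC(=O)/C=C/C(C)C)c4)n2)CSCC3)c1`: 25300 nM
Compound 2 `CC(C)/C=C/C(=O)Nc1cccc(Oc2nc(Nc3cccc(C#N)c3)nc3c2CSCC3)c1`: 35900 nM
Compound 3 `C/C=C/C(=O)Nc1cccc(Oc2nc(Nc3ccc(OC)nc3)nc3c2CSCC3)c1`: 8040 nM

Lower numbers mean stronger inhibition, so compound 3 is the most potent of the three. Compound 1 and compound 2 both stand higher than it by more than the usual scatter of repeated measurements.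

Compound 4 `COc1ccc(Nc2nc3c(c(Oc4cccc(NC(=O)/C=C/C(C)C)c4)n2)CSCC3)cn1` has not yet been measured. It differs from compound 3 by one change: isopropyl in place of methyl on a double-bonded chain carbon bound to a double-bonded chain carbon.

Within the data shown here, no measured step isolates this change. Among the measured compounds shown here, the only step available, a 1.4-fold higher number from compound 1 to compound 2 (0.15 log units; within the scatter), involves a different group and lies within the scatter, so it offers only a hint: the group swapped there made no clear difference. The better clue is that compound 1 and compound 2 already carry the isopropyl, and both have higher numbers than compound 3. That clue is imperfect, since those two compounds also differ from compound 3 elsewhere. A rise in this assay is therefore expected, though a smaller one than a full move to their level, and the expected step is a 2.2-fold higher number from compound 3 to compound 4 (0.35 log units; beyond the scatter). For compound 4 the estimated value is 18000 nM, with an expected range of 8000 nM to 40000 nM.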

Compound 4, half-maximal inhibitory concentration: 24200 nM
Compound 4: the middle estimate sits 1.3-fold (0.13 log units) below what was measured, within the range that was stated.
By their numbers in this assay, from the lowest: compound 3; then compounds 4, 1 and 2 (each within the scatter of the next).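

In this assay, among these compounds, the step of a 3.0-fold higher number from compound 3 to compound 4 (0.48 log units; beyond the scatter) is the first comparison in which isopropyl in place of methyl is the only change, and it links this swap on the chain carbon to weaker inhibition, beyond the scatter. With isopropyl in place, the group on the nitrogen makes no clear difference: 6-methoxypyridin-3-yl in place of 3-cyanophenyl gives a 1.5-fold lower number from compound 2 to compound 4 (0.17 log units; within the scatter) and 6-methoxypyridin-3-yl in place of 3-methoxyphenyl gives a 1.0-fold lower number from compound 1 to compound 4 (0.02 log units; within the scatter) and so these three isopropyl compounds cannot be told apart in this assay. Nothing at hand offers an explanation for the step that comes with the isopropyl.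

The compounds shown carry only methyl and isopropyl at this place, so it remains open how a plain hydrogen, an ethyl, a longer chain or a chain ending in an amine would behave. Among the compounds shown here, the methyl-to-isopropyl step is also seen only with 6-methoxypyridin-3-yl on the nitrogen, and whether it holds with 3-methoxyphenyl or 3-cyanophenyl there is still an open question.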